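Alpha-2C series: formyl replacing cyclopropyloxy on the aryl ether

The source may hold more compounds than are shown below. What is called first, only, known or untested is meant among the compounds shown, and "the series" means these compounds.

Working notes on the series. The shared core carries a substituted aromatic ring, and three compounds have been measured in an assay on CHO cells for displacement of a labelled ligand from Alpha-2C adrenergic receptor (Homo sapiens); on this read-out lower numbers stand for stronger inhibition and higher numbers for weaker inhibition. Compound 1 `CCc1ccccc1OC(C)C1=NCCN1` gives 288 nM. Compound 2 `C=C(C)c1ccccc1OC(C)C1=NCCN1` gives 603 nM. Compound 3 `CC(Oc1ccccc1OC1CC1)C1=NCCN1` gives 676 nM, the highest of the three numbers in this assay; its nearest neighbour is compound 2, within the scatter, and its furthest is compound 1, with a 2.3-fold higher number from compound 1 to compound 3 (0.37 log units; beyond the scatter).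

The next step goes from compound 3 to compound 4 `CC(Oc1ccccc1C=O)C1=NCCN1`: formyl in place of cyclopropyloxy on an aromatic carbon. Of the measured steps, a 2.3-fold higher number from compound 1 to compound 3 (0.37 log units; beyond the scatter) and a 1.1-fold higher number from compound 2 to compound 3 (0.05 log units; within the scatter) touch the same aromatic carbon, and the other step there is a 2.1-fold higher number from compound 1 to compound 2 (0.32 log units; beyond the scatter). None of the three involves formyl, so the change is not covered by any measured pair; what the data show is that three different groups at this position stay within a narrow band of numbers in this assay.

On that basis compound 4 is expected to land near compound 3, with a step of a 1.2-fold higher number from compound 3 to compound 4 (0.07 log units; within the scatter), that is, nothing clearly beyond the scatter in either direction, the range kept wide. The estimate for compound 4 in this assay is 800 nM, between 300 nM and 2500 nM.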

Compound 4, inhibition constant: 8710 nM
Beside the measured number, compound 4's estimate is 11-fold (1.04 log units) below it; the measured number lies above the stated range.
By their numbers in this assay, from the lowest: compound 1; then compounds 2 and 3 (each within the scatter of the next); then compound 4.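

Formyl is the first group at this aromatic carbon to bring a large step in this assay (a 13-fold higher number from compound 3 to compound 4 (1.11 log units; beyond the scatter)), and the picture is the same from the other two groups (a 14-fold higher number from compound 2 to compound 4 (1.16 log units; beyond the scatter) and a 30-fold higher number from compound 1 to compound 4 (1.48 log units; beyond the scatter)). The position is therefore not indifferent to what it carries: the modest steps among ethyl, 1-methylethenyl and cyclopropyloxy do not extend to formyl, all three steps run towards weaker inhibition, and the hydrogen-bond acceptor count does not separate the two groups in the step from cyclopropyloxy, since each has the same count. Nothing at hand gives a measured reason for this large step.

From the compounds shown here alone, whether the large step belongs to formyl alone or also appears with other carbonyl-bearing groups, such as acetyl, a carboxylic acid or a primary amide, remains open. Also open, going by these compounds, is how this assay would read for a hydroxymethyl group, an amine or a nitrile on this aromatic carbon, and whether a longer chain such as propyl would keep the number near that of the ethyl compound.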